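2-Chloro-5-nitrophenyl in Place of 3,5-Dichlorophenyl

The source may hold more compounds than are shown below. What is called first, only, known or untested is meant among the compounds shown, and "the series" means these compounds.

Three measured compounds share one core and differ only in the aryl group on a carbonyl carbon: compound 1 `O=C1c2ccccc2C(=O)N1CCOC(=S)N(C(=O)c1ccccc1[N+](=O)[O-])c1ccc(Cl)cc1`, compound 2 `O=C1c2ccccc2C(=O)N1CCOC(=S)N(C(=O)c1ccc(C(F)(F)F)cc1)c1ccc(Cl)cc1` and compound 3 `O=C1c2ccccc2C(=O)N1CCOC(=S)N(C(=O)c1cc(Cl)cc(Cl)c1)c1ccc(Cl)cc1`. In an ADME assay on MT4 cells (Homo sapiens) for cytotoxicity, read by MTT assay (a lower number here means that less compound is tolerated, a higher number that more compound is tolerated), compound 1 gives 21000 nM, compound 2 gives 10000 nM and compound 3 gives 32000 nM. Compound 3 therefore stands level with compound 1, as 3,5-dichlorophenyl in place of 2-nitrophenyl gives a 1.5-fold higher number from compound 1 to compound 3 (0.18 log units; within the scatter). It stands apart from compound 2, with a 3.2-fold higher number from compound 2 to compound 3 (0.51 log units; beyond the scatter), while the remaining comparison gives a 2.1-fold lower number from compound 1 to compound 2 (0.32 log units; beyond the scatter).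

Compound 4 `O=C1c2ccccc2C(=O)N1CCOC(=S)N(C(=O)c1cc([N+](=O)[O-])ccc1Cl)c1ccc(Cl)cc1` has not yet been measured in this assay. It carries 2-chloro-5-nitrophenyl in place of 3,5-dichlorophenyl on a carbonyl carbon. For the measured compounds named here, no measured step makes exactly this change. Going by the values given here, the nearest guide is compound 1, the only measured compound with a nitrophenyl group, at 21000 nM. The three measured steps are all modest or smaller, so no large move is expected, and the direction is only weakly indicated. The expected change is a 1.5-fold lower number from compound 3 to compound 4 (0.16 log units; within the scatter). For compound 4 the estimated value is 22000 nM, with an expected range from 10000 nM to 45000 nM.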

Compound 4, half-maximal cytotoxic concentration: 45000 nM
For compound 4 the middle estimate is 2.0-fold (0.31 log units) below the measured one; measured number inside the range.
By their numbers in this assay, from the lowest: compound 2; then compounds 1, 3 and 4 (each within the scatter of the next, the first and the last beyond it).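

In this assay, putting 2-chloro-5-nitrophenyl in place of 3,5-dichlorophenyl on the carbonyl carbon leaves the number level (a 1.4-fold higher number from compound 3 to compound 4 (0.15 log units; within the scatter)), so this change brings no readable shift even though the entering group carries a nitro group and the leaving group does not. For the compounds shown here, compound 1 had been the only nitro-bearing member and stood level with compound 3, but the two nitro-bearing aryl groups now separate (a 2.1-fold higher number from compound 1 to compound 4 (0.33 log units; beyond the scatter)), so the presence of a nitro group does not by itself set the number at this position, and the gap to the 4-(trifluoromethyl)phenyl group of compound 2 is the widest step in the set (a 4.5-fold higher number from compound 2 to compound 4 (0.65 log units; beyond the scatter)). No measurement is available that would explain why these aryl groups differ.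

All four compounds carry a substituted phenyl group at this carbonyl carbon, with chlorine, nitro or trifluoromethyl as the substituents. Going by these compounds, it remains open how the number would respond to a phenyl group bearing an amine or a carboxylic acid, or to a simple alkyl chain in place of the aromatic ring.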